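Working notes: a pentafluoroethyl analogue of compound 2

The source may hold more compounds than are shown below. What is called first, only, known or untested is meant among the compounds shown, and "the series" means these compounds.

Measured so far in a functional assay on DU-145 cells (Homo sapiens) for antiproliferative activity, read by propidium iodide staining, with a stated time of 96 h (a lower number here means a stronger inhibitor, a higher number a weaker inhibitor), as follows
- compound 1 `CC(O)(CSc1cccc(C(F)(F)F)c1)C(=O)Nc1cccc(S(F)(F)(F)(F)F)c1` gives 19100 nM
- compound 2 `CC(O)(CSc1cc(C(F)(F)F)cc(C(F)(F)F)c1)C(=O)Nc1cccc(S(F)(F)(F)(F)F)c1` gives 9400 nM
- compound 3 `CC(O)(CS(=O)(=O)c1ccc(OC(F)(F)F)cc1)C(=O)Nc1ccc(S(F)(F)(F)(F)F)cc1` gives 39300 nM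

Compound 2 has the lowest number of the three in this assay, with both gaps beyond the scatter. Compound 4 `CC(O)(CSc1cc(C(F)(F)F)cc(C(F)(F)F)c1)C(=O)Nc1cccc(C(F)(F)C(F)(F)F)c1` has not been measured. It differs from compound 2 by a group of 7 heavy atoms (2 carbon, 5 fluorine; no ring) in place of a group of 6 heavy atoms (5 fluorine, 1 sulfur; no ring), on an aromatic carbon, with 1,1,2,2,2-pentafluoroethyl on an aromatic carbon, meta to a large group. For the measured compounds named here, no measured step covers this exchange. Going by the values given here, the one measured step, a 2.0-fold lower number from compound 1 to compound 2 (0.31 log units; beyond the scatter), is modest and concerns a different group, so it bears only loosely. The expected step is a 1.0-fold lower number from compound 2 to compound 4 (0.02 log units; within the scatter) and so stays within the scatter. Compound 4 is estimated at 9000 nM, with a range of 3500 nM to 24000 nM expected.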

Compound 4, half-maximal inhibitory concentration: 8900 nM
Estimate against measurement, compound 4: 1.0-fold (0.00 log units) above; the measured number falls inside the stated range.
By their numbers in this assay, from the lowest: compounds 4 and 2 (each within the scatter of the next); then compound 1; then compound 3.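

In this assay, 1,1,2,2,2-pentafluoroethyl in place of the group of 5 fluorine and 1 sulfur, on an aromatic carbon meta to a large group, gives a 1.1-fold lower number from compound 2 to compound 4 (0.02 log units; within the scatter), so the two groups read alike here. The earlier step concerned trifluoromethyl elsewhere in the molecule and gave no reading at this position. No measurement on hand accounts for this equivalence.

As far as these compounds go, whether an amine, a carboxylic acid or a longer perfluoroalkyl chain at this position would read alike remains open.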